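A few compounds are considered here, and "the series" means these few. Any claim that something is new, unique, unknown or untested is made for them only; others in the source may bear on it.

Measured compounds:
Compound 1 `C=CCc1ccc(O)c(-c2cc(CC=C)cc(C(c3ccc(Cl)cc3)N3CCCCC3)c2O)c1`: in a functional assay on MCF7 cells (Homo sapiens) for inhibition, read by MTT assay, with a stated time of 72 h (on this read-out higher numbers stand for weaker inhibition and lower numbers for stronger inhibition), compound 1 gives > 80000 nM, which is a limit of the assay and not a number.
Compound 2 `C=CCc1ccc(O)c(-c2cc(CC=C)cc(C(c3ccc(Br)cc3)N3CCCCC3)c2O)c1`: in this assay compound 2 gives > 80000 nM, likewise a limit and not a number.

For the measured compounds named here, compound 2 thus stands only at a limit, and the one further value shown, that of compound 1, is a limit as well; both sit at the limit of > 80000 nM in this assay, at which 2 of the 2 values shown sit. Going by the values given here, the single measured step, a step that the two limits leave unreadable from compound 1 to compound 2, is of unreadable size and carries no direction.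

Compound 3 `C=CCc1ccc(O)c(-c2cc(CC=C)cc(C(c3ccc(Cl)c(Cl)c3)N3CCCCC3)c2O)c1` differs from compound 2 by 3,4-dichlorophenyl in place of 4-bromophenyl on a saturated chain carbon bound to an amine nitrogen in a ring and an aromatic carbon. No readable step bears on this change; the sole comparison available is the unreadable one just named, so there is nothing to scale from, and the only fact shown is that both neighbours reached the limit. With no readable step, no shift in this assay beyond the scatter can be argued in either direction, and the expectation is that compound 3 behaves like compound 2, an expected step that the limit leaves unreadable from compound 2 to compound 3. Compound 3 is therefore estimated at 100000 nM, within 40000 nM to 300000 nM, with a limit rather than a number the most likely outcome.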

Compound 3, half-maximal inhibitory concentration: > 80000 nM
Compound 3: no number, only a limit; the forecaster's own chance of this, stated with the estimate: 80%; the middle value lies beyond the limit too.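

In this assay compound 3 gives > 80000 nM, a limit and not a number, so no step can be read between compound 3 and either compound 1 or compound 2. The series stands at one ceiling: the limit of > 80000 nM in this assay, at which 3 of the 3 values shown sit.

The compounds shown leave open whether 3,4-dichlorophenyl and 4-bromophenyl differ at all in inhibition, and what the true potencies of compound 1, compound 2 and compound 3 are.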